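This account rests on a few compounds, and the source may have more. Where it says the series, first, only, none or still open, it means among the compounds named here.

Of the compounds shown here, three built on one shared core have been read in a functional assay on RAW264.7 cells (Mus musculus) for inhibition, read by Griess assay, with stated times of 1 h and 24 h; a lower number here means a stronger inhibitor, a higher number a weaker inhibitor. Compound 1 (`CCOc1ccc(C(O)C2OC(=O)c3c(OC)cc(OC)cc32)cc1`) gives > 10000 nM, which is a limit of the assay and not a number. Compound 2 (`CCCOc1ccc(C(O)C2OC(=O)c3c(OC)cc(OC)cc32)cc1`) gives 9260 nM. Compound 3 (`CCOCCOc1ccc(C(O)C2OC(=O)c3c(OC)cc(OC)cc32)cc1`) gives > 10000 nM, which is likewise only a limit. Compound 3 therefore stands at the limit of > 10000 nM in this assay, at which 2 of the 3 values shown sit.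

Compound 4 (`COc1cc(OC)c2c(c1)C(C(O)c1ccc(OCc3ccc(Br)cc3)cc1)OC2=O`) has 4-bromophenyl in place of ethoxymethyl on a saturated chain carbon bound to an oxygen on an aromatic ring, so that 2-ethoxyethoxy becomes (4-bromobenzyl)oxy: 4-bromophenyl in place of ethoxymethyl on a saturated chain carbon bound to an oxygen on an aromatic ring.

The measured steps at this place offer little guidance. They are an at least 1.0-fold higher number from compound 2 to compound 3 (0.03 log units; that floor lies within the scatter), an at least 1.0-fold lower number from compound 1 to compound 2 (0.03 log units; that floor lies within the scatter), and a step that the two limits leave unreadable from compound 1 to compound 3. None of them brings in a ring, so they give no measured size for this change. For the measured compounds named here, compound 2, at 9260 nM, is the only compound with a number, which suggests that a value of similar size is the most reasonable expectation. Only a small move towards a lower number is expected in this assay, and it may not exceed the scatter. The expected step is an at least 1.2-fold lower number from compound 3 to compound 4 (0.09 log units; that floor lies within the scatter). For compound 4 the estimated value is 8000 nM, with an expected range of 3000 nM to 20000 nM.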

Compound 4, half-maximal inhibitory concentration: 6530 nM
For compound 4 the middle estimate is 1.2-fold (0.09 log units) above the measured one; low and high end bracket the measured number.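

The only ring at this place, 4-bromophenyl on a saturated chain carbon bound to an oxygen on an aromatic ring, leaves the reading in this assay close to that of the propoxy compound: the result is a 1.4-fold lower number from compound 2 to compound 4 (0.15 log units; within the scatter), so compound 2 and compound 4 cannot be told apart. Against the two compounds that carry a limit, the readings are an at least 1.5-fold lower number from compound 3 to compound 4 (0.18 log units; that floor lies within the scatter) and an at least 1.5-fold lower number from compound 1 to compound 4 (0.18 log units; that floor lies within the scatter); these are floors only, and neither shows a separation from the chain compounds. What compound 4 adds is a second readable number and a first measure for a ring at this place, showing that this change gives no step beyond the scatter, while the set still rests heavily on limits: the limit of > 10000 nM in this assay, at which 2 of the 4 values shown sit.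

As far as these compounds go, the true values of compound 1 and compound 3 stay open, and with them the full size of the steps to compound 4. Also open, from the compounds shown here alone, is whether the bromine plays any part, which a plain benzyl, a 4-chlorobenzyl or a 4-methoxybenzyl group at this place could begin to show.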